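Triazole isomers on the salicylic acid core, rat paw edema

This account rests on a few compounds, and the source may have more. Where it says the series, first, only, none or still open, it means among the compounds named here.

Measured so far:
compound 1 `O=C(O)c1cc(-n2ccnn2)ccc1O` — 150 mg/kg
compound 2 `O=C(O)c1cc(-c2cc[nH]n2)ccc1O` — > 250 mg/kg
compound 3 `O=C(O)c1cc(-c2ccno2)ccc1O` — 110 mg/kg

In a functional assay on the whole organism for inhibition, with Rattus norvegicus as the target, read by paw edema (on this read-out lower numbers stand for an effect already at smaller amounts and higher numbers for an effect only at larger amounts of compound), compound 1 gives 150 mg/kg. Compound 3 gives 110 mg/kg, and the step of a 1.4-fold lower number from compound 1 to compound 3 (0.13 log units; within the scatter) lies within the scatter, so the two cannot be told apart. Compound 2 gives only a limit of the assay, > 250 mg/kg; the step of an at least 1.6-fold higher number from compound 1 to compound 2 (0.22 log units; that floor lies within the scatter) has a floor that lies within the scatter, and the limit of > 250 mg/kg in this assay, at which 1 of the 3 values shown sits, marks that limit. The step of an at least 2.2-fold lower number from compound 2 to compound 3 (0.35 log units; beyond the scatter) is the only one beyond the scatter.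

Compound 4 `O=C(O)c1cc(-n2nccn2)ccc1O` differs from compound 1 by 2H-1,2,3-triazol-2-yl in place of 1H-1,2,3-triazol-1-yl on an aromatic carbon. Within the data shown here, none of the three measured steps exchanges one 1,2,3-triazolyl attachment for the other; the nearest comparisons are the small changes among five-membered rings already seen, of which only the step from compound 2 to compound 3 exceeded the scatter. The change to compound 4 keeps the same atoms and the same counts of donors and acceptors, so no step beyond the scatter is expected in this assay in either direction. For compound 4 the expected value is 150 mg/kg, with a range from 70 mg/kg to 300 mg/kg; this amounts to an expected step of no change at the digits printed from compound 1 to compound 4 (within the scatter).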

Compound 4, dose for half-maximal effect: 150 mg/kg
Beside the measured number, compound 4's estimate shows no gap at the digits printed; the measured number falls inside the stated range.
By their numbers in this assay, from the lowest: compounds 3, 1 and 4 (each within the scatter of the next). At a limit, above all of these: compound 2.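

In this assay, the first direct test of the two 1,2,3-triazolyl attachments, at the place para to a hydroxy group and meta to a carboxy group, shows no readable difference between 1H-1,2,3-triazol-1-yl and 2H-1,2,3-triazol-2-yl, with no change at the digits printed from compound 1 to compound 4 (within the scatter). The 2H-1,2,3-triazol-2-yl and 1,2-oxazol-5-yl rings also cannot be told apart at this place, with a 1.4-fold higher number from compound 3 to compound 4 (0.13 log units; within the scatter), so this new ring joins the other two in a group of compounds lying within the scatter of the next. The step of an at least 1.6-fold lower number from compound 2 to compound 4 (0.22 log units; that floor lies within the scatter) rests on a limit of the assay and does not separate that pair: the limit of > 250 mg/kg in this assay, at which 1 of the 4 values shown sits.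

Going by these compounds, all four compounds carry a five-membered aromatic ring at this place, so how an open-chain amine, a longer alkyl chain or a saturated ring such as morpholine would read there remains open. On these data alone, the carboxy and hydroxy groups are also the same throughout, so what this assay would give with a methyl ester or an amide in place of the carboxy group remains open too.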